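Notes on the amide series: methyl in place of hydrogen

This account rests on a few compounds, and the source may have more. Where it says the series, first, only, none or still open, it means among the compounds named here.

Two members are measured and both sit at the assay limit. In a functional assay on A549 cells (Homo sapiens) for cytotoxicity, read by CCK-8 assay, with a stated time of 24 h (a lower number here means a stronger inhibitor, a higher number a weaker inhibitor), compound 1 `C=C1CCC(c2csc(/C=C(\C)C(N)=O)c2)CC1` gives > 50000 nM, a limit and not a number. Compound 2 `C/C(=C\c1cc(-c2ccccc2)co1)C(N)=O` gives > 50000 nM in this assay, again only a limit. For the measured compounds named here, compound 2 thus stands with the other measured member at the limit of > 50000 nM in this assay, at which 2 of the 2 values shown sit, and no step between measured compounds is available. Compound 3 `C/C(=C\c1cc(-c2ccc(C)cc2)co1)C(N)=O` differs from compound 2 by methyl in place of hydrogen on an aromatic carbon. No step beyond the scatter is expected from this change. Compound 3 is expected to stay at the limit, with a number no higher from compound 2 to compound 3 (the limit leaves the size open) taken as no change. The estimate for compound 3 in this assay is 50000 nM, within 20000 nM to 200000 nM.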

Compound 3, half-maximal inhibitory concentration: > 50000 nM
Compound 3 was reported as a limit (the forecaster's own chance of this, stated with the estimate: 85%); the middle value lies on the limit itself.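

No step can be read from compound 2 to compound 3: both results are limits, not numbers. The compounds shown leave open whether methyl in place of hydrogen changes cytotoxicity, and whether any member gives a measurable value.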